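The source may hold more compounds than are shown below. What is called first, only, known or untested is meant among the compounds shown, and "the series" means these compounds.

In a functional assay on SK-MEL-5 cells (Homo sapiens) for inhibition, read by sulforhodamine B assay, with a stated time of 48 h, tested at 1 uM (a higher number here means a weaker effect of the compound at the concentration tested, a lower number a stronger effect), compound 3 `COc1cc(Cl)cc(-c2nn(-c3cccc(NC(=O)Nc4ccc(Cl)c(Cl)c4)c3)cc2-c2ccncc2)c1` gives 88%, the highest of the three numbers seen. Its nearest neighbour is compound 1 `COc1cc(Cl)cc(-c2nn(-c3cccc(NC(=O)Nc4ccc(Cl)c(C(F)(F)F)c4)c3)cc2-c2ccncc2)c1` at 83%, a gap within the scatter; the furthest is compound 2 `COc1cc(Cl)cc(-c2nn(-c3cccc(NC(=O)Nc4cc(C(F)(F)F)cc(C(F)(F)F)c4)c3)cc2-c2ccncc2)c1` at 50%, a gap beyond it. Going by the values given here, the only single-change step recorded, a number 5 percentage points higher from compound 1 to compound 3 (within the scatter), lies within the scatter. Compound 4 `COc1cc(Cl)cc(-c2nn(-c3cccc(NC(=O)Nc4cccc(C(F)(F)F)c4)c3)cc2-c2ccncc2)c1` differs from compound 3 by 3-(trifluoromethyl)phenyl in place of 3,4-dichlorophenyl on an amide-type nitrogen. Among the compounds with values here, no measured step removes a chlorine in this way, so the expectation rests on the small step of a number 5 percentage points higher from compound 1 to compound 3 (within the scatter) and on the lower number of compound 2. Compound 4 is therefore expected to give 82%, between 65% and 98%. The expected step of a number 6 percentage points lower from compound 3 to compound 4 (within the scatter) is small.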

Compound 4, a percentage reported as activity, at one concentration (the size of the read-out at that concentration, not a potency): 80%
Beside the measured number, compound 4's estimate is 2 percentage points above it, within the range that was stated.
By their numbers in this assay, from the lowest: compound 2; then compounds 4, 1 and 3 (each within the scatter of the next).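

In this assay 3-(trifluoromethyl)phenyl in place of 3,4-dichlorophenyl on the amide-type nitrogen gives a number 8 percentage points lower from compound 3 to compound 4 (within the scatter) and hydrogen in place of chloro gives a number 3 percentage points lower from compound 1 to compound 4 (within the scatter) so neither change moves the read-out measurably. Hydrogen in place of trifluoromethyl instead gives a number 30 percentage points higher from compound 2 to compound 4 (beyond the scatter) and this links the stronger effect of compound 2 to that added trifluoromethyl. Among these single changes, only this one goes beyond the scatter.

As far as these compounds go, whether an amine or a carboxylic acid on that aromatic ring would match compound 2 stays open. Nothing available explains the size of these steps.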